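The compounds below may be only part of what the source reports. "The series", "measured", "known", "first", "only" and "open" are said of these compounds alone.

Compound 1 `Cn1ncc2c(NC(=O)NCc3cc(C(F)(F)F)nn3-c3ccc(F)cc3)cccc21` is a urea whose aryl group carries a fluoro substituent, and in an assay on CHO-K1 cells for antagonist activity at transient receptor potential cation channel subfamily V member 1 (Homo sapiens), read by FLIPR and calcium flux, with a stated time of 6 min (a higher number here means a weaker inhibitor, a lower number a stronger inhibitor), compound 1 gives 8.4 nM. Compound 2 `Cn1ncc2c(NC(=O)NCc3cc(C(F)(F)F)nn3-c3ccc(C(F)(F)F)cc3)cccc21` is its counterpart in which the change trifluoromethyl in place of fluoro on an aromatic carbon has been made, and in this assay compound 2 gives 3.9 nM. That single change produced a 2.2-fold lower number from compound 1 to compound 2 (0.33 log units; beyond the scatter).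

Compound 3 `CC(C)(C)c1cc(CNC(=O)Nc2cccc3[nH]ncc23)n(-c2cccc(F)c2)n1` carries a different core; how it relates to the core of compound 1 is not broken down here. In this assay compound 3 gives 1.3 nM, the lowest of the three measured numbers, and it sits beyond the scatter from both compound 1 and compound 2.

Compound 4 `CC(C)(C)c1cc(CNC(=O)Nc2cccc3[nH]ncc23)n(-c2cccc(C(F)(F)F)c2)n1` has not been measured. It differs from compound 3 by trifluoromethyl in place of fluoro on an aromatic carbon. This is the same kind of change that was made from compound 1 to compound 2, though not the same: in compound 1 the fluoro sits para to a large group, whereas in compound 3 it sits meta to a large group.

For compound 4 the step expected in this assay is a 2.2-fold lower number from compound 3 to compound 4 (0.34 log units; beyond the scatter). This expectation rests on the measured step of a 2.2-fold lower number from compound 1 to compound 2 (0.33 log units; beyond the scatter), taken as a guide for a change of the same kind on a different core, with some allowance for the difference in placement. Compound 4 is therefore expected to give an estimated value of 0.6 nM, with a likely range from 0.25 nM to 1.5 nM.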

Compound 4, inhibition constant: 0.3 nM
The estimate for compound 4 lay 2.0-fold (0.30 log units) above the measured number; measured number inside the range.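

In this assay, putting trifluoromethyl in place of fluoro gave a 4.3-fold lower number from compound 3 to compound 4 (0.64 log units; beyond the scatter), so the change lowered the number on the core of compound 3 as it had on the core of compound 1. The two steps run the same way, and their sizes cannot be told apart: the same change on two cores in this assay, a 2.2-fold lower number (0.33 log units; beyond the scatter) from compound 1 to compound 2 and a 4.3-fold lower number (0.64 log units; beyond the scatter) from compound 3 to compound 4, 2.0-fold (0.30 log units) apart, within the scatter of two such steps. This shows the direction of the change carrying over between these two cores in this assay, but two pairs cannot show that it would carry to a further core, and since the group sits in a different place on each core, they cannot separate the contribution of the core from that of the placement.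

The compounds shown leave open whether the step would stay the same if the group sat in one and the same place on both cores, since only the pair on the core of compound 3 has it meta to a large group. They also leave open how other groups on that aromatic carbon, such as a chloro, a methoxy or a nitrile, would compare with fluoro and trifluoromethyl on either core.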